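The source may hold more compounds than are shown below. What is called first, only, known or untested is meant among the compounds shown, and "the series" means these compounds.

In a functional assay, read by fluorescence and spectrophotometry, with a stated time of 1 h (a higher number here means that more compound is needed for the effect, a lower number that less compound is needed), three compounds with a shared core have been measured. Compound 1 `O=S(=O)(/C=C/c1ccc(O)c(O)c1)CCC1CCCCC1` gives 9800 nM, compound 2 `O=S(=O)(/C=C/c1ccc(O)c(O)c1)CCCCCCCCO` gives 6700 nM, and compound 3 `O=S(=O)(/C=C/c1ccc(O)c(O)c1)CCC1CCCC1` gives 6800 nM. Compound 2 therefore stands level with the other two, since all three values lie within the scatter of each other.

Compound 4 `O=S(=O)(/C=C/c1ccc(O)c(O)c1)CCCCCCCCCO` differs from compound 2 by one change, hydroxymethyl in place of hydroxy on a saturated chain carbon, eight bonds along the chain from a sulfonyl sulfur. Within the data shown here, no measured step makes this exact change. The closest evidence comes from swaps in the same part of the molecule. Replacing cyclohexyl with 6-hydroxyhexyl gives a 1.5-fold lower number from compound 1 to compound 2 (0.17 log units; within the scatter), replacing cyclohexyl with cyclopentyl gives a 1.4-fold lower number from compound 1 to compound 3 (0.16 log units; within the scatter), and replacing 6-hydroxyhexyl with cyclopentyl gives a 1.0-fold higher number from compound 2 to compound 3 (0.01 log units; within the scatter). All of these stay within the scatter, so no change beyond the scatter is expected in this assay. The estimated step is a 1.0-fold lower number from compound 2 to compound 4 (0.01 log units; within the scatter). Compound 4 is expected at 6500 nM, with an estimated range of 3200 nM to 13000 nM.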

Compound 4, half-maximal effective concentration: 7500 nM
For compound 4 the middle estimate is 1.2-fold (0.06 log units) below the measured one; low and high end bracket the measured number.
By their numbers in this assay, from the lowest: compounds 2, 3, 4 and 1 (each within the scatter of the next).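

In this assay, putting hydroxymethyl in place of hydroxy on a saturated chain carbon, eight bonds along the chain from a sulfonyl sulfur, gives a 1.1-fold higher number from compound 2 to compound 4 (0.05 log units; within the scatter) and so stays within the scatter. The earlier steps shown here swapped whole groups, such as cyclohexyl for cyclopentyl, whereas this one keeps the hydroxy-bearing chain and only extends it, and at this size of change the assay does not separate the two compounds. Nothing available here accounts for this result.

On these data alone, whether an amine or a carboxylic acid in place of hydroxymethyl on that same carbon would shift the number beyond the scatter remains open. So does the effect of a much longer chain, or of a plain alkyl chain with no hydroxy group.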